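The source may hold more compounds than are shown below. What is called first, only, known or untested is meant among the compounds shown, and "the series" means these compounds.

In a functional assay on HEL cells (Homo sapiens) for inhibition, read by MTT assay, with a stated time of 48 h (on this read-out lower numbers stand for stronger inhibition and higher numbers for weaker inhibition), compound 1 `O=S(=O)(c1ccccc1)c1c(OCCCCCCO)no[n+]1[O-]` gives 2160 nM and compound 2 `O=C(CCCOc1no[n+]([O-])c1S(=O)(=O)c1ccccc1)NO` gives 670 nM, so compound 2 holds the lower of the two numbers. Compound 3 `O=C(CCCCOc1no[n+]([O-])c1S(=O)(=O)c1ccccc1)NO` differs from compound 2 by one change, ((hydroxycarbamoyl)methyl in place of hydroxycarbamoyl on a saturated chain carbon, three bonds along the chain from an oxygen on an aromatic ring), in which 3-(hydroxycarbamoyl)propyl becomes 4-(hydroxycarbamoyl)butyl. For the measured compounds named here, only one measured step bears on this, a 3.2-fold lower number from compound 1 to compound 2 (0.51 log units; beyond the scatter), and it swapped the chain end, so no measured step shows what lengthening the chain alone does. The estimated step is therefore small, a 1.2-fold lower number from compound 2 to compound 3 (0.09 log units; within the scatter), and is not expected to go beyond the scatter. Compound 3 is expected at 550 nM, with an estimated range of 200 nM to 1500 nM.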

Compound 3, half-maximal inhibitory concentration: 1030 nM
Beside the measured number, compound 3's estimate is 1.9-fold (0.27 log units) below it; measured number inside the range.
By their numbers in this assay, from the lowest: compounds 2 and 3 (each within the scatter of the next); then compound 1.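

In this assay, going from 3-(hydroxycarbamoyl)propyl to 4-(hydroxycarbamoyl)butyl gives a 1.5-fold higher number from compound 2 to compound 3 (0.19 log units; within the scatter), so these two chain lengths cannot be told apart at this position. With the chain at 4-(hydroxycarbamoyl)butyl, putting hydroxycarbamoyl in place of 2-hydroxyethyl still gives a 2.1-fold lower number from compound 1 to compound 3 (0.32 log units; beyond the scatter), which shows that the gain seen with compound 2 survives this change of chain, though it stays modest. No measurement here accounts for either step. As far as these compounds go, whether a longer chain such as 5-(hydroxycarbamoyl)pentyl would shift the number remains open, as does the effect of a carboxylic acid in place of the hydroxycarbamoyl end.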